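Benzyl to 4-chlorobenzyl on compound 2

This account rests on a few compounds, and the source may have more. Where it says the series, first, only, none or still open, it means among the compounds named here.

Among the measured compounds shown here, in a functional assay on RS4-11 cells (Homo sapiens) for inhibition, read by CCK-8 assay, with a stated time of 48 h, tested at 20 uM (a higher number here means more inhibition of growth at the concentration tested, a lower number less inhibition of growth), compound 2 `N#C/C(=C\c1ccccc1OS(=O)(=O)c1ccccc1[N+](=O)[O-])C(=O)Nc1nnc(Cc2ccccc2)s1` gives 71% and stands highest of the two numbers so far, with compound 1 `N#C/C(=C\c1ccccc1OS(=O)(=O)c1ccc([N+](=O)[O-])cc1)C(=O)Nc1nnc(Cc2ccccc2)s1` at 57% as its only neighbour. For the measured compounds named here, the one measured step is a number 14 percentage points higher from compound 1 to compound 2 (beyond the scatter) and comes with 2-nitrophenyl in place of 4-nitrophenyl on a sulfonyl sulfur. Compound 3 `N#C/C(=C\c1ccccc1OS(=O)(=O)c1ccccc1[N+](=O)[O-])C(=O)Nc1nnc(Cc2ccc(Cl)cc2)s1` keeps that 2-nitrophenyl and differs from compound 2 elsewhere: chloro in place of hydrogen on an aromatic carbon (benzyl to 4-chlorobenzyl). Going by the values given here, no measured pair changes this place, so the one step serves only as a loose guide to how far a single change can move the number. No step beyond the scatter is expected. The estimated step is a number 3 percentage points higher from compound 2 to compound 3 (within the scatter) and no larger than the measured one. For compound 3 the expected value in this assay is 74% with an estimated range of 58% to 88% at the concentration tested.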

Compound 3, percent growth inhibition at one concentration: 65%
For compound 3 the middle estimate is 9 percentage points above the measured one; low and high end bracket the measured number.
By their numbers in this assay, from the lowest: compounds 1, 3 and 2 (each within the scatter of the next, the first and the last beyond it).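

Benzyl to 4-chlorobenzyl is the first change read at this end of the molecule, and chloro on the aromatic carbon para to a large group gives a number 6 percentage points lower from compound 2 to compound 3 (within the scatter) in this assay. Among the compounds shown here, at this position, then, a single chloro produces no step beyond the scatter, and the one such step remains a number 14 percentage points higher from compound 1 to compound 2 (beyond the scatter) on the sulfonyl side. Nothing at hand explains the result for this change.

As far as these compounds go, one chloro at one place is a single point, so it stays open whether an amine or a carboxylic acid on the same ring, or a longer chain in place of benzyl, would move the number beyond the scatter. Also open, from the compounds shown here alone, is whether chloro at this position gives a similar step when 4-nitrophenyl sits on the sulfonyl sulfur.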